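The source may hold more compounds than are shown below. What is called first, only, known or untested is meant among the compounds shown, and "the series" means these compounds.

Notes on the series. The shared core is shown by compound 3 `CN(C)CCCCCSC1=Nc2ccccc2C(CC(=O)NCc2ccc(F)cc2)N1c1ccc(-c2ccc(F)cc2)cc1`, which in an assay on cells for inhibition of Voltage-dependent T-type calcium channel subunit alpha-1G (Homo sapiens), read by patch clamp (a higher number here means a weaker inhibitor, a lower number a stronger inhibitor), gives 400 nM; this is the lowest of the three numbers in hand. Compound 1 `CN(C)CCCCCSC1=Nc2ccccc2C(CC(=O)NCc2ccc(F)cc2)N1c1ccc(-c2ccccc2)cc1` gives 27400 nM in this assay, and compound 2 `CN(C)CCCCCSC1=Nc2ccccc2C(CC(=O)NCc2ccccc2)N1c1ccccc1` gives 18500 nM. Within the data shown here, the only step between compounds that differ in a single place is a 69-fold lower number from compound 1 to compound 3 (1.84 log units; beyond the scatter), so the fluorine gained in compound 3 carries the whole of its advantage over compound 1; compound 2 differs from compound 3 in two places and gives no clean step, only the two values side by side.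

Compound 4 `CN(C)CCCCCSC1=Nc2ccccc2C(CC(=O)NCc2ccc(F)cc2)N1c1ccccc1` has not been measured. Against compound 3 the change is hydrogen in place of 4-fluorophenyl on an aromatic carbon. Among the measured compounds shown here, no measured step removes this group outright, but two points frame it: compound 1, which keeps the group without its fluorine, sits at 27400 nM, and compound 2, which lacks the group altogether and carries one further change elsewhere, sits at 18500 nM. Both lie far above compound 3, so a large rise is expected, of about a 45-fold higher number from compound 3 to compound 4 (1.65 log units; beyond the scatter). Compound 4 is therefore estimated at 18000 nM in this assay, with a range of 6000 nM to 50000 nM.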

Compound 4, half-maximal inhibitory concentration: 555000 nM
The estimate for compound 4 lay 31-fold (1.49 log units) below the measured number, and the stated range ends below it.
By their numbers in this assay, from the lowest: compound 3; then compounds 2 and 1 (each within the scatter of the next); then compound 4.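

In this assay, among these compounds, the group on this aromatic carbon carries far more weight than the earlier compounds could show: hydrogen in place of 4-fluorophenyl gives a 1400-fold higher number from compound 3 to compound 4 (3.14 log units; beyond the scatter), and even the plain phenyl group counts, since its loss gives a 20-fold higher number from compound 1 to compound 4 (1.31 log units; beyond the scatter). A bare phenyl at this place is thus already worth a large step before any fluorine is added, and the fluorine of compound 3 adds a further large step on top of it. Fluoro in place of hydrogen has no single direction in this series, since on a different ring it gives a 30-fold higher number from compound 2 to compound 4 (1.48 log units; beyond the scatter), against the fall seen with the 4-fluorophenyl group: the same change on two cores in this assay, a 69-fold lower number (1.84 log units; beyond the scatter) from compound 1 to compound 3 and a 30-fold higher number (1.48 log units; beyond the scatter) from compound 2 to compound 4, 2100-fold (3.31 log units) apart, beyond the scatter of two such steps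

Open, as far as these compounds go, is whether chloro or methoxy in place of that fluorine would keep a number as low as that of compound 3, and whether a small group such as methyl on this aromatic carbon would fall between hydrogen and phenyl. Also open, from the compounds shown here alone, is what the fluorine on the other ring does when the 4-fluorophenyl group is present, as the rise is known only on the core of compound 2.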